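Ring-junction hydroxy on compound 2: expected cytotoxicity

The source may hold more compounds than are shown below. What is called first, only, known or untested is meant among the compounds shown, and "the series" means these compounds.

Measured compounds:
compound 1 `C=C(C)[C@H]1[C@@H]2C[C@@H](C)CC[C@H]2C(C)=C[C@H]1O`: 0.79 ug/mL
compound 2 `C=C(C)[C@@H]1C(=O)C=C(C)[C@@H]2CC[C@H](C)C[C@@H]12`: > 50 ug/mL
compound 3 `C=C(C)[C@@H]1C=C[C@](C)(O)[C@@H]2CC[C@H](C)C[C@H]21`: > 50 ug/mL

In a functional assay on A549 cells (Homo sapiens) for cytotoxicity, read by MTT assay (a higher number here means that more compound is needed for the effect, a lower number that less compound is needed), compound 1 gives 0.79 ug/mL. Compound 2 reaches only the limit of the assay, > 50 ug/mL, and no number. Compound 3 likewise stops at the limit of the assay, > 50 ug/mL. Compound 2 thus stands at the limit, where two of the three values shown sit (the limit of > 50 ug/mL in this assay, at which 2 of the 3 values shown sit), while compound 1 alone gives a number.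

Compound 4 `C=C(C)[C@@H]1C(=O)C=C(C)[C@@]2(O)CC[C@H](C)C[C@@H]12` is not yet measured. It differs from compound 2 by hydroxy in place of hydrogen on a saturated ring carbon. Going by the values given here, no step between measured compounds is available, so the size of the change cannot be read from a neighbouring pair; compound 3, which also carries a hydroxy on a ring carbon, rests at the limit. The expectation is that compound 4 stays near the limit, with no step beyond the scatter: the expected step is an at least 1.1-fold lower number from compound 2 to compound 4 (0.04 log units; that floor lies within the scatter). For compound 4 in this assay the estimate is 45 ug/mL, with a range from 15 ug/mL to 100 ug/mL.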

Compound 4, concentration for half-maximal effect: > 50 ug/mL
Compound 4 was reported as a limit (the forecaster's own chance of this, stated with the estimate: 70%); at least 1.1-fold (0.04 log units) between middle value and limit.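

Compound 2 and compound 4 both rest at a limit in this assay, so no step can be read for hydroxy in place of hydrogen on a saturated ring carbon: the limit of > 50 ug/mL in this assay, at which 3 of the 4 values shown sit.

The compounds shown leave open whether this replacement changes cytotoxicity at all, and by how much.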